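A few compounds are considered here, and "the series" means these few. Any claim that something is new, unique, unknown or untested is made for them only; others in the source may bear on it.

The starting point is compound 1 (`O=C(NCc1ccc(S(=O)(=O)N2CCCCC2)cc1)c1cc2cnccc2s1`), an amide tested in an ADME assay on microsomes from liver (Mus musculus) for metabolic stability, read by LC-MS, with a stated time of 30 min, tested at 1 uM; a lower number here means that less of the compound is left, a higher number that more of the compound is left. Compound 1 gives "below limit of detection" (no number reported), so there is no number for it. Compound 2 (`O=C(NCc1ccc(S(=O)(=O)c2cccc(C(F)(F)F)c2)cc1)c1cc2cnccc2[nH]1`) differs from compound 1 in more than one place, and in this assay compound 2 gives 49%. That result provides a number, but it cannot isolate the effect of any single structural change.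

Compound 3 (`O=C(NCc1ccc(S(=O)(=O)N2CCCCC2)cc1)c1cnc2nccn2c1`) has not yet been measured. It keeps the rest of compound 1 and changes only the group on a carbonyl carbon: a group of 9 heavy atoms (6 carbon, 3 nitrogen; one five-membered aromatic ring with 2 hetero atoms, one six-membered aromatic ring with 2 hetero atoms) in place of a group of 9 heavy atoms (7 carbon, 1 nitrogen, 1 sulfur; one five-membered aromatic ring with 1 hetero atom, one six-membered aromatic ring with 1 hetero atom), on a carbonyl carbon. For the measured compounds named here, no measured pair shows what this swap does, so the size of the step remains uncertain. A moderate upward step in this assay is expected, though it is a cautious guess. Going by the values given here, the only numerical guide is compound 2 at 49%, and compound 3 is expected to fall short of that mark or come near it. Another result reported only as a limit also remains possible. For compound 3, the estimated value is 22%, with an expected range from 3% to 55%.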

Compound 3, percent of the compound remaining: 0.28%
Beside the measured number, compound 3's estimate is 21.7 percentage points above it; the measured number lies below the stated range.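

In this assay compound 1 has no number and compound 3 gives 0.28% as its value, so no step can be read between compound 1 and compound 3. These compounds leave open how much the swap of the group on the carbonyl carbon changes the percent remaining. No available evidence bears on this result.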